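Piperidin-1-yl for isobutylamino in a series at its limit

The source may report more compounds than this note shows. Statements on the series, on what has been measured and on what is new or still open speak of the compounds shown alone.

In a functional assay on HOP-62 cells (Homo sapiens) for inhibition, read by trypan blue exclusion, with a stated time of 48 h (a lower number here means a stronger inhibitor, a higher number a weaker inhibitor), compound 3 (`CCCCCCC[C@H](O)C/C=C/CCC(=O)NCC(C)C`) gives > 100000 nM, which is a limit and not a number. Compound 1 (`CCCCCCC[C@@H](C/C=C/CCC(=O)N1CCCCC1)OC`) gives > 100000 nM, also a limit. Compound 2 (`CCCCCCC[C@H](C/C=C/CCC(=O)N1CCCCC1)OC`) gives > 100000 nM, again a limit. The whole picture so far is thus (the limit of > 100000 nM in this assay, at which 3 of the 3 values shown sit), and none of these compounds can be ranked against another.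

Compound 4 (`CCCCCCC[C@H](O)C/C=C/CCC(=O)N1CCCCC1`) is reached from compound 3 by a single exchange, with piperidin-1-yl in place of isobutylamino on a carbonyl carbon. Going by the values given here, only one measured step is available, a step that the two limits leave unreadable from compound 1 to compound 2. It offers little guidance, since it reflects the fact that compounds 1 and 2 differ only in the configuration as drawn and its size cannot be read. Among the compounds with values here, no measured step therefore gives a size for the exchange on the carbonyl carbon.

The expectation rests mainly on compound 3, which stands at the limit of > 100000 nM. With no evidence of a gain, no step beyond the usual scatter is expected in this assay, in either direction, and the assay may well report only a limit again. The estimated a number no higher from compound 3 to compound 4 (the limit leaves the size open) reflects this. For compound 4 the expected value is 100000 nM, with an estimated range of 40000 nM to 250000 nM.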

Compound 4, half-maximal inhibitory concentration: > 100000 nM
Compound 4 gave a limit, no number; the forecaster's own chance of this, stated with the estimate: 80%; the middle value sits exactly at the limit.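

In this assay compound 4 gives > 100000 nM, which is a limit and not a number. The steps to compound 4 from compound 3 and from compound 1 therefore cannot be read, and the picture stands as follows: the limit of > 100000 nM in this assay, at which 4 of the 4 values shown sit. The compounds shown leave open how piperidin-1-yl and isobutylamino on a carbonyl carbon truly compare.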